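The compounds below may be only part of what the source reports. "The series", "measured", "known", "first", "only" and "open" are said of these compounds alone.

Working notes on the thienopyrimidine-type series, assessed in a functional assay on MDA-MB-436 cells (Homo sapiens) for antiproliferative activity, read by MTT assay, with a stated time of 48 h; a lower number here means a stronger inhibitor, a higher number a weaker inhibitor. Compound 1 `C=CS(=O)(=O)N1CCN(c2ncnc3sc(-c4cccc5ncccc45)cc23)CC1` gives 25900 nM in this assay. Compound 2 `C=CS(=O)(=O)N1CCN(c2ncnc3sc(-c4cn(S(=O)(=O)c5ccccc5)c5ccccc45)cc23)CC1` gives 38000 nM in this assay. Compound 3 `CCS(=O)(=O)N1CCN(c2ncnc3sc(-c4ccc(N5CCN(C)CC5)cc4)cc23)CC1` gives 10600 nM in this assay. Among the three measured numbers compound 3 stands lowest, and its gaps to compound 1 and to compound 2 both lie beyond the scatter, so compound 3 is the strongest inhibitor of the three so far; no pair of these three differs in only one place, so no single structural step can be read from them.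

Compound 4 `CN1CCN(c2ccc(-c3cc4c(N5CCN(C(=O)Nc6ccccc6F)CC5)ncnc4s3)cc2)CC1` has not yet been measured. It differs from compound 3 as follows: (2-fluorophenyl)carbamoyl in place of ethylsulfonyl on an amine nitrogen in a ring. Among the measured compounds shown here, with no measured step to lean on, the expectation is a moderate move toward a lower number, beyond the scatter but not large. This step is expected to be a 2.1-fold lower number from compound 3 to compound 4 (0.33 log units; beyond the scatter). Compound 4 is therefore expected to give about 5000 nM in this assay, within a range from 1000 nM to 25000 nM.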

Compound 4, half-maximal inhibitory concentration: 14300 nM
For compound 4 the middle estimate is 2.9-fold (0.46 log units) below the measured one; the measured number falls inside the stated range.
By their numbers in this assay, from the lowest: compounds 3, 4, 1 and 2 (each within the scatter of the next, the first and the last beyond it).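

In this assay, (2-fluorophenyl)carbamoyl in place of ethylsulfonyl on this amine nitrogen in a ring gives a 1.3-fold higher number from compound 3 to compound 4 (0.13 log units; within the scatter), so compound 3 and compound 4 cannot be told apart by this read-out. The entering group brings a six-membered aromatic ring of carbon only and a hydrogen-bond donor that ethylsulfonyl lacks, and this position still holds both groups with numbers inside the scatter of each other. Nothing measured here bears on why the two read alike.

From the compounds shown here alone, it remains open whether any group on this nitrogen can move the number beyond the scatter, for instance a short chain ending in an amine or a carboxylic acid. Also open, going by these compounds, is what the fluorine contributes, which a plain phenylcarbamoyl on the same nitrogen would address.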